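The source may hold more compounds than are shown below. What is called first, only, known or untested is meant among the compounds shown, and "the series" means these compounds.

Measured in an in vitro ADME assay on microsomes from liver (Homo sapiens) for metabolic stability, using NADPH; a higher number here means faster removal of the compound, a lower number slower removal:
- compound 1 `COc1ccc(OC(F)(F)F)cc1Cn1c(C(=O)NCC(C)(C)CO)cc2cc(C#N)ccc21`: 69 mL.min-1.g-1
- compound 2 `CC(C)(CO)CNC(=O)c1cc2cc(C#N)ccc2n1Cc1cc(Cl)cc(Cl)c1`: 103 mL.min-1.g-1
- compound 3 `COc1ccc(C)cc1Cn1c(C(=O)NCC(C)(C)CO)cc2cc(C#N)ccc21`: 191 mL.min-1.g-1

Compound 3 sits at the upper end of this small set. Two steps define its place: a 1.9-fold higher number from compound 2 to compound 3 (0.27 log units; within the scatter), and a 2.8-fold higher number from compound 1 to compound 3 (0.44 log units; beyond the scatter).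

The next case is compound 4 `Cc1ccc(Cl)cc1Cn1c(C(=O)NCC(C)(C)CO)cc2cc(C#N)ccc21`, with 5-chloro-2-methylphenyl in place of 2-methoxy-5-methylphenyl on a saturated chain carbon bound to an aromatic nitrogen. It carries 5-chloro-2-methylphenyl in place of 2-methoxy-5-methylphenyl on a saturated chain carbon bound to an aromatic nitrogen.

The closest guide is a change of group at this same place, involving 3,5-dichlorophenyl: a 1.9-fold higher number from compound 2 to compound 3 (0.27 log units; within the scatter). The other step, a 2.8-fold higher number from compound 1 to compound 3 (0.44 log units; beyond the scatter), offers weaker guidance, as it exchanges trifluoromethoxy for methyl and leaves the methoxy in place. Among the measured compounds shown here, no measured step shows the loss of the methoxy alone, so the expectation is loose. A modest fall is expected, near the edge of the scatter, and the estimate is a 1.5-fold lower number from compound 3 to compound 4 (0.18 log units; within the scatter). Compound 4 is expected at 125 mL.min-1.g-1, with an estimated range of 65 mL.min-1.g-1 to 230 mL.min-1.g-1.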

Compound 4, intrinsic clearance in microsomes: 119 mL.min-1.g-1
The estimate for compound 4 lay 1.1-fold (0.02 log units) above the measured number; the measured number falls inside the stated range.
By their numbers in this assay, from the lowest: compounds 1, 2, 4 and 3 (each within the scatter of the next, the first and the last beyond it).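

In this assay, the exchange of 2-methoxy-5-methylphenyl for 5-chloro-2-methylphenyl on a saturated chain carbon bound to an aromatic nitrogen gives a 1.6-fold lower number from compound 3 to compound 4 (0.21 log units; within the scatter), and the exchange of 3,5-dichlorophenyl for the same group gives a 1.2-fold higher number from compound 2 to compound 4 (0.06 log units; within the scatter). Both steps stay within the scatter, as does the step linking compound 2 and compound 3, so these three groups are not told apart at this place, and the swap of methoxy and methyl for methyl and chlorine on the ring leaves the number inside that scatter. Nothing given here offers an explanation for this result.

Going by these compounds, it remains open whether an amine or a carboxylic acid on this ring would move the number beyond the scatter. Also open, on these data alone, is whether trifluoromethoxy, present only in compound 1, would keep its step on a ring without the methoxy.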